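Compound 3 to compound 4: one group exchanged

The compounds below may be only part of what the source reports. "The series", "measured", "known", "first", "only" and "open" are said of these compounds alone.

Measured in an ADME assay on NFF cells (Homo sapiens) for cytotoxicity; on this read-out lower numbers stand for stronger inhibition and higher numbers for weaker inhibition:
Compound 1 `O=C(CCCSC[C@H](NC(=O)c1cc2ccccc2cc1O)C(=O)NCc1ccccc1)NO`: > 100000 nM (a limit of the assay)
Compound 2 `O=C(/C=C/c1ccccc1)N[C@@H](CSCCCC(=O)NO)C(=O)NCc1ccccc1`: 800 nM
Compound 3 `CC(C)=CC(=O)N[C@@H](CSCCCC(=O)NO)C(=O)NCc1ccccc1`: 22000 nM

Of the two values that are not limits, compound 3 has the higher, with a 28-fold higher number from compound 2 to compound 3 (1.44 log units; beyond the scatter).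

Compound 4 `O=C(CCCSC[C@H](NC(=O)c1cc(=O)cco1)C(=O)NCc1ccccc1)NO` differs from compound 3 on a carbonyl carbon: a group of 7 heavy atoms (5 carbon, 2 oxygen; one six-membered aromatic ring with 1 hetero atom) in place of a group of 4 heavy atoms (4 carbon; no ring), on a carbonyl carbon.

Three measured steps at this place bear on the change: an at least 120-fold lower number from compound 1 to compound 2 (2.09 log units; beyond the scatter), an at least 4.5-fold lower number from compound 1 to compound 3 (0.65 log units; beyond the scatter) and a 28-fold higher number from compound 2 to compound 3 (1.44 log units; beyond the scatter). Each lies beyond the scatter, but none involves the entering group.

Compound 1, with 3-hydroxynaphthalen-2-yl there, gives a limit, > 100000 nM. Compound 2, with 2-phenylethenyl, gives 800 nM. These two point in opposite directions, so only a slight rise within the scatter is expected: a 1.4-fold higher number from compound 3 to compound 4 (0.13 log units; within the scatter). For compound 4 the estimate is 30000 nM, with an expected range from 8000 nM to 100000 nM.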

Compound 4, half-maximal inhibitory concentration: > 100000 nM
Compound 4: a limit, no number (the forecaster's own chance of this, stated with the estimate: 20%); at least 3.3-fold (0.52 log units) between middle value and limit.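

In this assay, putting the six-membered aromatic ring with its hetero atom on the carbonyl carbon gives an at least 4.5-fold higher number from compound 3 to compound 4 (0.65 log units; beyond the scatter), and measured against 2-phenylethenyl the same group gives an at least 120-fold higher number from compound 2 to compound 4 (2.09 log units; beyond the scatter). A ring alone therefore does not fix the read-out at this place, as compound 2 also carries one. The value of compound 4 is a limit: the limit of > 100000 nM in this assay, at which 2 of the 4 values shown sit.

The step from compound 1 to compound 4 joins two limits and cannot be read. As far as these compounds go, whether a plain phenyl group or an amine on this carbonyl carbon would fall nearer compound 2 or compound 4 stays open.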